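Compound 4: Does Isopropoxy Keep the Number High?

This account rests on a few compounds, and the source may have more. Where it says the series, first, only, none or still open, it means among the compounds named here.

- Compound 1 `COc1ccc(C2=C(c3cc(OC)c(OC)c(OC)c3)C(=O)C(O)C2)cc1` gives 6.3 ug/mL
- Compound 2 `COc1ccc(C2=C(c3cc(OC)c(OC)c(OC)c3)C(=O)C(O)C2)cc1NC(=O)c1ccccc1` gives > 100 ug/mL (a limit)
- Compound 3 `COc1ccc(C2=C(c3cc(OC)c(OC)c(OC)c3)C(=O)C(O)C2)cc1Cl` gives > 100 ug/mL (a limit)

All three values come from an ADME assay on HEK293 cells (Homo sapiens) for cytotoxicity, read by MTT assay, with a stated time of 72 h; a lower number here means a stronger inhibitor, a higher number a weaker inhibitor. Only compound 1 has a true number there. Going by these compounds, compound 3 has only a limit, so its exact value is unknown, and it shares that position with compound 2: the limit of > 100 ug/mL in this assay, at which 2 of the 3 values shown sit.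

Compound 4 `COc1ccc(C2=C(c3cc(OC)c(OC)c(OC)c3)C(=O)C(O)C2)cc1OC(C)C` carries isopropoxy in place of chloro on an aromatic carbon.

Going by the values given here, two measured steps bear on this change. Chloro in place of hydrogen gave an at least 15-fold higher number from compound 1 to compound 3 (1.20 log units; beyond the scatter), and benzamido in place of hydrogen gave an at least 15-fold higher number from compound 1 to compound 2 (1.20 log units; beyond the scatter). Both are large and beyond the scatter. The remaining comparison, a step that the two limits leave unreadable from compound 2 to compound 3, adds no size. Since compound 2 and compound 3 both moved far upward from compound 1, isopropoxy is expected to keep the number high, with little or no real fall.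

The expected change is an at least 1.4-fold lower number from compound 3 to compound 4 (0.15 log units; that floor lies within the scatter). The estimate for compound 4 is 70 ug/mL, with an expected range from 15 ug/mL to 200 ug/mL.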

Compound 4, half-maximal inhibitory concentration: > 100 ug/mL
Compound 4: no number, only a limit (the forecaster's own chance of this, stated with the estimate: 55%); at least 1.4-fold (0.15 log units) between middle value and limit.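

Compound 4 gives only a limit, but the step from hydrogen can still be read in this assay: isopropoxy in place of hydrogen gives an at least 15-fold higher number from compound 1 to compound 4 (1.20 log units; beyond the scatter). Isopropoxy is now the third group on this aromatic carbon, after benzamido and chloro, to go with a large rise in the number, and no compound shown goes against that pattern. The steps among compound 2, compound 3 and compound 4 cannot be read, and the three compounds now sit together: the limit of > 100 ug/mL in this assay, at which 3 of the 4 values shown sit.

Going by these compounds, how far the true values of these three compounds lie past the limit stays open, and so does any order among their groups. Also open, on these data alone, is whether a different group on this carbon, such as an amine or a hydroxyl, would bring the number back toward that of compound 1, 6.3 ug/mL.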